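Bromo for fluoro on the sulfonyl aryl ring

The source may report more compounds than this note shows. Statements on the series, on what has been measured and on what is new or still open speak of the compounds shown alone.

Measured so far:
compound 1, `COc1cc(N(Cc2ccc(F)cc2)S(=O)(=O)c2ccc(C)cc2)cc(OC)c1OC`: 3750 nM
compound 2, `COc1cc(N(Cc2ccc(Br)cc2)S(=O)(=O)c2ccc(C)cc2)cc(OC)c1OC`: 1610 nM
compound 3, `COc1cc(N(Cc2nc3ccccc3[nH]2)S(=O)(=O)c2ccc(F)cc2)cc(OC)c1OC`: 5680 nM

In a functional assay on MGC-803 cells (Homo sapiens) for inhibition, read by MTT assay, with a stated time of 48 h (on this read-out lower numbers stand for stronger inhibition and higher numbers for weaker inhibition), compound 1 gives 3750 nM. Compound 2 differs by bromo in place of fluoro on an aromatic carbon, and this change gives a 2.3-fold lower number from compound 1 to compound 2 (0.37 log units; beyond the scatter). Compound 3 gives 5680 nM; the difference between the cores of compound 1 and compound 3 is not broken down here. Compound 3 and compound 1 lie within the scatter of each other, while the gap from compound 3 to compound 2 is beyond it.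

Compound 4, `COc1cc(N(Cc2nc3ccccc3[nH]2)S(=O)(=O)c2ccc(Br)cc2)cc(OC)c1OC`, has not been measured. It differs from compound 3 by bromo in place of fluoro on an aromatic carbon. The place is described in the same words as for the step from compound 1 to compound 2, so it is the same change, occurring twice among these compounds; cut one bond further out, however, it reads (4-fluorophenyl)sulfonyl to (4-bromophenyl)sulfonyl in one case and 4-fluorobenzyl to 4-bromobenzyl in the other. Since the ring carrying the halogen is not the same ring, the earlier step is only a partial guide.

For compound 4 in this assay a step of a 1.8-fold lower number from compound 3 to compound 4 (0.25 log units; within the scatter) is expected, somewhat smaller than the measured one, because compound 2 showed a 2.3-fold lower number from compound 1 to compound 2 (0.37 log units; beyond the scatter) on a different ring. The estimate for compound 4 is 3200 nM, expected to fall between 1300 nM and 7500 nM.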

Compound 4, half-maximal inhibitory concentration: 2190 nM
Compound 4: middle estimate off by 1.5-fold (0.16 log units), on the high side, within the range that was stated.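

In this assay, bromo in place of fluoro on an aromatic carbon gives a 2.6-fold lower number from compound 3 to compound 4 (0.41 log units; beyond the scatter), and the step matches the earlier one on the other core: the same change on two cores in this assay, a 2.3-fold lower number (0.37 log units; beyond the scatter) from compound 1 to compound 2 and a 2.6-fold lower number (0.41 log units; beyond the scatter) from compound 3 to compound 4, 1.1-fold (0.05 log units) apart, within the scatter of two such steps

This shows that, for these two pairs, the change carries from one core to the other with no difference in size that can be told from the scatter, even though the halogen sits on a 4-fluorobenzyl group in one pair and on a (4-fluorophenyl)sulfonyl group in the other. It does not establish a rule for the series: the agreement rests on just two pairs in a single cell assay, the two steps are on different rings, and the numbers give no reason for the gain.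

Still open, as far as these compounds go, is whether chloro or iodo in the same place would follow the bromo step, and whether a more different group there, such as an amine or a carboxylic acid, would keep or lose it. Also open, from the compounds shown here alone, is whether bromo on both the benzyl ring and the sulfonyl aryl ring of one compound would add up to the sum of the two steps.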